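Chloro on the second phenyl: step from compound 3 to compound 4

The compounds below may be only part of what the source reports. "The series", "measured", "known", "first", "only" and "open" are said of these compounds alone.

Measured so far in a functional assay on HT-29 cells (Homo sapiens) for cytotoxicity, read by MTT assay, with a stated time of 72 h; on this read-out lower numbers stand for stronger inhibition and higher numbers for weaker inhibition:
- compound 1, `O=C(Nc1nc2ccccc2s1)c1cn(-c2ccccc2)nc1-c1ccccc1`, gives 16800 nM
- compound 2, `O=C(Nc1nc2ccc(F)cc2s1)c1cn(-c2ccccc2)nc1-c1ccccc1`, gives 9800 nM
- compound 3, `O=C(Nc1nc2ccc(Cl)cc2s1)c1cn(-c2ccccc2)nc1-c1ccccc1`, gives 7810 nM

Compound 3 holds the lowest number of the three; compound 2 sits within the scatter of it, while a 2.2-fold lower number from compound 1 to compound 3 (0.33 log units; beyond the scatter) is a modest step beyond the scatter. Compound 4, `O=C(Nc1nc2ccc(Cl)cc2s1)c1cn(-c2ccccc2)nc1-c1ccc(Cl)cc1`, differs from compound 3 by chloro in place of hydrogen on an aromatic carbon. Going by the values given here, the steps that bear on it are the earlier additions of a halogen to an aromatic carbon: a 1.7-fold lower number from compound 1 to compound 2 (0.23 log units; within the scatter) and a 2.2-fold lower number from compound 1 to compound 3 (0.33 log units; beyond the scatter), both small, though made on a different ring of the shared core. A comparable, at most modest, move toward a lower number is therefore expected, a 1.6-fold lower number from compound 3 to compound 4 (0.19 log units; within the scatter). Compound 4 is estimated at 5000 nM, with a range from 2500 nM to 12000 nM.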

Compound 4, half-maximal inhibitory concentration: 4550 nM
For compound 4 the middle estimate is 1.1-fold (0.04 log units) above the measured one; the range from low to high includes it.
By their numbers in this assay, from the lowest: compounds 4, 3, 2 and 1 (each within the scatter of the next, the first and the last beyond it).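

In this assay the change from phenyl to 4-chlorophenyl gives a 1.7-fold lower number from compound 3 to compound 4 (0.23 log units; within the scatter) on a different ring from the one that carries the halogen in compound 2 and compound 3. This second ring therefore takes a chloro with the number staying within the scatter of compound 3, so the change shows no firm gain. No measurement at hand explains this result.

On these data alone, whether an amine or a methoxy group at this same place would move the number beyond the scatter remains open, as does the outcome with a carboxylic acid there.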